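Acetyl in Place of Dimethylamino: An Expected Shift in Cytotoxicity

This account rests on a few compounds, and the source may have more. Where it says the series, first, only, none or still open, it means among the compounds named here.

Measured so far, in a functional assay on COLO 205 cells (Homo sapiens) for cytotoxicity, read by sulforhodamine B assay, with a stated time of 48 h, tested at 1 uM; on this read-out lower numbers stand for a stronger effect and higher numbers for a weaker effect at the one concentration tested:
- compound 1, `COc1cc(C)cc(-c2c(-c3ccnc(-c4ccc(N(C)C)cc4)c3)cnn2CC#N)c1`: 3%
- compound 2, `COc1cc(C)cc(-c2nn(CC#N)cc2-c2ccc(-c3cccc(C(C)=O)c3)nc2)c1`: -55%
- compound 3, `Cc1cc(O)cc(-c2nn(CC#N)cc2-c2ccnc(-c3ccc(N(C)C)cc3)c2)c1`: -59%

Of these three, compound 1 gives the highest number in this assay, and so the weakest effect; compound 2 and compound 3 both sit far lower, each beyond the usual scatter, so compound 1 is clearly the least active of the measured set.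

Compound 4, `COc1cc(C)cc(-c2c(-c3ccnc(-c4ccc(C(C)=O)cc4)c3)cnn2CC#N)c1`, has not yet been measured. Compared with compound 1 it differs in one place: acetyl in place of dimethylamino on an aromatic carbon. Going by the values given here, no pair of measured compounds shows this exact change, so its effect cannot be read directly. Compound 2, however, also carries an acetyl and gives -55%, a far stronger effect than compound 1.

On that basis a shift toward lower numbers is expected, estimated as a number 33 percentage points lower from compound 1 to compound 4 (beyond the scatter). Compound 4 is therefore expected to give about -30%, with a likely range from -65% to 5%.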

Compound 4, a percentage reported as activity, at one concentration (the size of the read-out at that concentration, not a potency): -78%
Compound 4: middle estimate off by 48 percentage points, on the high side; measured number outside the range, below it.
By their numbers in this assay, from the lowest: compound 4; then compounds 3 and 2 (each within the scatter of the next); then compound 1.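

In this assay, exchanging 4-(dimethylamino)phenyl for 4-acetylphenyl gives a number 81 percentage points lower from compound 1 to compound 4 (beyond the scatter), the first direct sign that the group at this position strongly affects the read-out on this core. The step is large even though the two groups have the same number of heavy atoms and hydrogen-bond acceptors, and neither carries a ring or a net charge, so matching those counts does not make the two groups interchangeable here. Nothing available explains why this exchange has such a large effect.

This single pair leaves open whether a primary amine, a carboxylic acid or a longer chain such as propanoyl would behave like acetyl at this position. It also leaves open whether the same exchange would give a similar step on a different core.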